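Adding a Third Methoxy Group to a Cytotoxic Chalcone

A few compounds are considered here, and "the series" means these few. Any claim that something is new, unique, unknown or untested is made for them only; others in the source may bear on it.

In a functional assay on NCI-H23 cells (Homo sapiens) for cytotoxicity, read by sulforhodamine B assay, with a stated time of 48 h, tested at 100 uM (a lower number here means a stronger effect, a higher number a weaker effect of the compound at the concentration tested), two compounds have been measured. Compound 1, `COc1ccc(-c2cc(/C=C/C(=O)c3ccc(OC)c(OC)c3)[nH]n2)cc1`, gives -73%. Compound 2, `COc1ccc(-c2cc(/C=C/C(=O)c3cc(OC)c(OC)c(OC)c3)[nH]n2)cc1OC`, gives -50%. Of these two numbers compound 2 stands highest, and its gap to compound 1 lies beyond the scatter, so compound 2 has the weaker effect of the pair at the concentration used. Among the measured compounds shown here, compound 1 and compound 2 differ in more than one place, so no single-site step between them is known.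

Compound 3, `COc1cc(C(=O)/C=C/c2cc(-c3cc(OC)c(OC)c(OC)c3)n[nH]2)cc(OC)c1OC`, has not yet been measured. It differs from compound 2 in one place: methoxy in place of hydrogen on an aromatic carbon. The aromatic ring that gains the group already carries two methoxy groups, so compound 3 has trimethoxy substitution on both outer rings.

For the measured compounds named here, no single-site step with a methoxy entering at this place has been measured, so the size and direction of the change can only be guessed. A small step is expected, from compound 2 to compound 3 of about a number 8 percentage points lower from compound 2 to compound 3 (within the scatter), which might not exceed the scatter. Compound 3 is estimated to give -58%, with a range from -88% to -20%.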

Compound 3, a percentage reported as activity, at one concentration (the size of the read-out at that concentration, not a potency): -62%
The estimate for compound 3 lay 4 percentage points above the measured number; the range from low to high includes it.
By their numbers in this assay, from the lowest: compound 1; then compound 3; then compound 2.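

In this assay, the change of methoxy in place of hydrogen on an aromatic carbon, ortho to a methoxy group and meta to a methoxy group, gives a number 12 percentage points lower from compound 2 to compound 3 (beyond the scatter), a modest step toward a stronger effect at the concentration tested. Among the compounds shown here, this is the first single-place step, so this position now has a measured direction and size, which the comparison of compound 1 with compound 2 could not provide. The added methoxy, which gives compound 3 trimethoxy substitution on both outer rings, does not weaken the effect here, but nothing available explains why the number moves.

This single step cannot show whether the gain belongs to methoxy itself or whether another group at the same place, such as hydroxy, fluorine or ethoxy, would give a similar, larger or opposite change. The read-out also comes from one concentration, so it leaves open how the potency of compound 2 and compound 3 compares and whether the same step would appear on other cells.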